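A Fluorine Added to the Methylphenyl Ring

The source may report more compounds than this note shows. Statements on the series, on what has been measured and on what is new or still open speak of the compounds shown alone.

Three compounds sharing one core were tested in an assay on isolated protein for displacement of a labelled ligand from metabotropic glutamate receptor 5 (Homo sapiens), with a stated time of 60 min, tested at 1 uM; on this read-out lower numbers stand for less inhibition and higher numbers for more inhibition at the one concentration tested (going by the name of the read-out). Compound 1 `Cc1ccc(S(=O)(=O)c2cnc3c(F)cccc3c2N2CCC(C)CC2)cc1` gives 93%, the highest of the three numbers. Compound 3 `COc1ccc2ncc(S(=O)(=O)c3cccc(C#N)c3)c(N3CCC(C)CC3)c2c1` gives 90%, a number within the scatter of compound 1, so the two cannot be ranked against each other. Compound 2 `CCN1CCN(c2c(S(=O)(=O)c3ccccc3)cnc3ccccc23)CC1` gives 1.7%, far below both. Compound 4 `Cc1ccc(S(=O)(=O)c2cnc3c(F)cccc3c2N2CCC(C)CC2)cc1F` differs from compound 1 in one place: fluoro in place of hydrogen on an aromatic carbon. Going by the values given here, because compound 1 already stands near the top of the read-out at 93%, there is little room for a higher number, and nothing among the measured compounds points to a drop beyond the scatter. The expected step from compound 1 to compound 4 is a number 3 percentage points lower from compound 1 to compound 4 (within the scatter), that is, none beyond the scatter. Compound 4 is therefore estimated at 90%, with a range from 78% to 98%.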

Compound 4, a percentage reported as inhibition, at one concentration (the size of the read-out at that concentration, not a potency): 93%
Estimate against measurement, compound 4: 3 percentage points below; low and high end bracket the measured number.
By their numbers in this assay, from the lowest: compound 2; then compounds 3, 1 and 4 (each within the scatter of the next).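

In this assay, swapping 4-methylphenyl for 3-fluoro-4-methylphenyl gives no change at the digits printed from compound 1 to compound 4 (within the scatter) and so shows that this position takes a fluoro group without a loss beyond the scatter. Going by these compounds alone, this is the first direct reading of a single change, though a gain would be hard to see so close to the top of the read-out. Nothing available here gives a reason for the result.

On these data alone, whether chloro, methoxy or an amine would be accepted at this carbon stays open. A single test concentration could also hide a difference in potency between compound 1 and compound 4.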